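This account rests on a few compounds, and the source may have more. Where it says the series, first, only, none or still open, it means among the compounds named here.

The series is tested in a functional assay with Cavia porcellus as the target; a higher number here means a weaker inhibitor, a lower number a stronger inhibitor. Compound 1, `C=C(C)C[N+](C)(C)c1cccc(O)c1`, reaches only the limit of this assay, reported as > 3000 nM. Compound 2, `CC(=O)Oc1ccccc1[N+](C)(C)Cc1ccccc1`, likewise gives only a limit, > 3000 nM. For the measured compounds named here, compound 3, `COc1ccc(C(=O)COc2ccc([N+](C)(C)C)cc2)cc1OC`, is the one member with a measured number: in this assay compound 3 gives 9800 nM. Compound 3 therefore stands as the only number shown, while the two companion values are limits rather than numbers. Two of the three values shown sit at the limit of > 3000 nM in this assay, at which 2 of the 3 values shown sit.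

The step to compound 4, `COc1ccc(C(=O)COc2ccc([N+](C)(C)Cc3ccccc3)cc2)cc1OC`, changes one place: phenyl in place of hydrogen on a saturated chain carbon bound to a nitrogen on an aromatic ring. Going by the values given here, no measured pair in the set shares this change, so its size cannot be read from the data. Compound 2 carries a benzyl on its nitrogen and compound 1 does not, but both sit at a limit, so they point in no direction. The expected step from compound 3 to compound 4 in this assay is a 1.2-fold lower number from compound 3 to compound 4 (0.09 log units; within the scatter), a change not expected to exceed the usual scatter. On this basis compound 4 is estimated at 8000 nM in this assay, with a likely range from 2500 nM to 30000 nM.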

Compound 4, half-maximal inhibitory concentration: 19400 nM
The estimate for compound 4 lay 2.4-fold (0.38 log units) below the measured number; measured number inside the range.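

In this assay, for the compounds shown here, the change from methyl to benzyl gives a 2.0-fold higher number from compound 3 to compound 4 (0.30 log units; within the scatter), the only step that can be read from two numbers. It shows that phenyl in place of hydrogen on a saturated chain carbon bound to a nitrogen on an aromatic ring, an entry of six carbon atoms in one aromatic ring, leaves the read-out within the scatter, so this position accepts the added ring with no change that this assay can separate from repeat measurement. Going by these compounds alone, compound 2 also carries a benzyl on its nitrogen, but it differs from the other compounds in more than one place and its value is a limit, so this pair remains the only reading of the change: the limit of > 3000 nM in this assay, at which 2 of the 4 values shown sit.

As far as these compounds go, whether the same holds for a longer chain such as propyl, for a cyclohexyl ring, or for a benzyl with a chlorine on its ring stays open. A single pair also cannot say whether the change would read alike on another core, such as one with an amide in place of the ketone carbonyl.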